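A few compounds are considered here, and "the series" means these few. Any claim that something is new, unique, unknown or untested is made for them only; others in the source may bear on it.

The series shares one core, shown in compound 1 `COc1cc(F)cc(-c2ccc(C(=O)N(Cc3cccc(OCCCCCC(=O)O)c3)C(C)C)cc2)c1`. In an ADME assay on HepG2 cells (Homo sapiens) for cytotoxicity, read by CellTiter-Glo and resazurin assay, with a stated time of 72 h (on this read-out lower numbers stand for an effect already at smaller amounts and higher numbers for an effect only at larger amounts of compound), compound 1 gives > 26000 nM, which is a limit of the assay rather than a number. Compound 2 `COc1ccc(F)c(-c2ccc(C(=O)N(Cc3cccc(OCCCCCC(=O)O)c3)C(C)C)cc2)c1` carries 2-fluoro-5-methoxyphenyl in place of 3-fluoro-5-methoxyphenyl on an aromatic carbon. In this assay compound 2 also gives only a limit, > 26000 nM. The step that the two limits leave unreadable from compound 1 to compound 2 therefore cannot be sized. Compound 3 `CCOC(=O)CCCCCOc1cccc(CN(C(=O)c2ccc(-c3cc(F)cc(OC)c3)cc2)C(C)C)c1` differs from compound 1 by ethyl in place of hydrogen on an oxygen next to a carbonyl group, and in this assay compound 3 likewise gives a limit, > 26000 nM. The step that the two limits leave unreadable from compound 1 to compound 3 is equally unreadable, since (the limit of > 26000 nM in this assay, at which 3 of the 3 values shown sit). Compound 4 `CCOC(=O)CCCCCOc1cccc(CN(C(=O)c2ccc(-c3cc(OC)ccc3F)cc2)C(C)C)c1` has not been measured; it differs from compound 3 by 2-fluoro-5-methoxyphenyl in place of 3-fluoro-5-methoxyphenyl on an aromatic carbon, the same change at the same place that separates compound 1 from compound 2. From compound 3 to compound 4 the expected step in this assay is a step that the limit leaves unreadable from compound 3 to compound 4, set beside the unreadable earlier one, and this expectation rests on (the limit of > 26000 nM in this assay, at which 3 of the 3 values shown sit). For compound 4 in this assay the estimate is 30000 nM, within 18000 nM to 70000 nM, and it is expected most probably to be reported as a limit once more.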

Compound 4, half-maximal effective concentration: > 26000 nM
Compound 4 ended at the assay's limit; the forecaster's own chance of this, stated with the estimate: 88%; the middle value lies beyond the limit too.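

No new step can be read in this assay: neither compound 3 to compound 4 nor compound 2 to compound 4 can be sized, as each pair joins two limits and not numbers: the limit of > 26000 nM in this assay, at which 4 of the 4 values shown sit.

The compounds shown leave open whether 2-fluoro-5-methoxyphenyl in place of 3-fluoro-5-methoxyphenyl, or ethyl in place of hydrogen, changes the read-out in this assay at all.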